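From chloro to nitro: working notes on compound 4

The source may hold more compounds than are shown below. What is called first, only, known or untested is meant among the compounds shown, and "the series" means these compounds.

Measured in a physicochemical assay for acid dissociation:
compound 1 `O=S(=O)(Nc1ccc(Cl)cc1)c1ccc(Cl)cc1` gives 8.3
compound 2 `Cc1ccc(NS(=O)(=O)c2ccc(Cl)cc2)cc1` gives 8.78
compound 3 `Nc1ccc(NS(=O)(=O)c2ccc(Cl)cc2)cc1` gives 9.76

Compound 1 stands lowest of the three (8.3). The next compound to consider is compound 4 `O=[N+]([O-])c1ccc(S(=O)(=O)Nc2ccc(Cl)cc2)cc1`, which has nitro in place of chloro on an aromatic carbon, para to a large group: nitro in place of chloro on an aromatic carbon.

Three measured steps offer some guidance: a number 0.48 log units higher from compound 1 to compound 2 (beyond the scatter), which is modest, a number 1.46 log units higher from compound 1 to compound 3 (beyond the scatter), which is large, and a number 0.98 log units higher from compound 2 to compound 3 (beyond the scatter), which is modest. They bear on this change only in part, since each concerns the other aromatic chloro position of compound 1 or its replacement, and none brings in nitro. They therefore give a scale but no direction, and the direction remains a judgement. A lower number is expected, opposite to the steps measured so far, with a size closer to the modest a number 0.48 log units higher from compound 1 to compound 2 (beyond the scatter) than to the large a number 1.46 log units higher from compound 1 to compound 3 (beyond the scatter).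

The expected change is a number 0.60 log units lower from compound 1 to compound 4 (beyond the scatter). For compound 4 the estimated value is 7.7, with an expected range from 7.3 to 8.1.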

Compound 4, acid dissociation constant: 6.24
Compound 4: the middle estimate sits 1.46 log units above what was measured; measured number below the stated range.
By their numbers in this assay, from the lowest: compound 4; then compound 1; then compound 2; then compound 3.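

In this assay, nitro in place of chloro on an aromatic carbon, para to a large group, gives a number 2.06 log units lower from compound 1 to compound 4 (beyond the scatter). Among the compounds shown here, this position therefore responds strongly to substitution, and this is the first step to go downward, since the steps from compound 1 to compound 2 and to compound 3 both go upward at the other chloro position. No measurement shown here accounts for the direction or size of this step.

As far as these compounds go, it remains open whether a nitrile or a carboxylic acid at this same position would also lower the number, and by how much compared with nitro. From the compounds shown here alone, it is also open whether nitro at the other chloro position of compound 1 would give a step of similar direction and size.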